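This account rests on a few compounds, and the source may have more. Where it says the series, first, only, none or still open, it means among the compounds named here.

Measured so far in an assay on cell membranes for displacement of a labelled ligand from Cholecystokinin receptor type A (Rattus norvegicus), read by CCK-8 assay, with a stated time of 2 h; a higher number here means a weaker inhibitor, a lower number a stronger inhibitor:
compound 1 `CC(C)N1C(=O)C=C(Cl)C1(O)c1ccccc1`, 200 nM
compound 2 `CC(C)N1C(=O)C=C(Cl)C1(O)c1ccc(Cl)cc1`, 300 nM
compound 3 `O=C1C=C(Cl)C(O)(c2ccc(Cl)cc2)N1C1CC1`, 4000 nM

Compound 1 gives the lowest number of the three in this assay. Its nearest neighbour is compound 2, reached by a 1.5-fold higher number from compound 1 to compound 2 (0.18 log units; within the scatter), a step within the scatter, so the two are not ordered against each other. Furthest from compound 1 stands compound 3, at 4000 nM.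

Compound 4 `O=C1C=C(Cl)C(O)(c2ccccc2)N1C1CCCC1` differs from compound 1 by cyclopentyl in place of isopropyl on an amide-type nitrogen in a ring. For the measured compounds named here, no measured step exchanges isopropyl for cyclopentyl. Going by the values given here, the only step that touches the same nitrogen is a 13-fold higher number from compound 2 to compound 3 (1.12 log units; beyond the scatter), where a three-membered ring replaced the isopropyl and the number rose sharply. Cyclopentyl is a five-membered ring of carbon only, a larger group than either isopropyl or cyclopropyl, and no compound in the series carries it, so that step is at best an indirect guide. On this basis the step of a 1.5-fold higher number from compound 1 to compound 4 (0.18 log units; within the scatter) is expected to be small, with a lean towards a higher number, and the range is set wide. Compound 4 is therefore estimated at 300 nM in this assay, between 80 nM and 1500 nM.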

Compound 4, half-maximal inhibitory concentration: 360 nM
Compound 4: middle estimate off by 1.2-fold (0.08 log units), on the low side, within the range that was stated.
By their numbers in this assay, from the lowest: compounds 1, 2 and 4 (each within the scatter of the next); then compound 3.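

At the amide-type nitrogen in a ring, this assay shows cyclopentyl exchanged for isopropyl with no change beyond the scatter, as a 1.8-fold higher number from compound 1 to compound 4 (0.26 log units; within the scatter). A carbocyclic ring on this nitrogen, and five carbon heavy atoms in place of three, therefore do not in themselves bring a large step in this series, so the large step seen with the other ring here, a 13-fold higher number from compound 2 to compound 3 (1.12 log units; beyond the scatter), cannot be read as a general result of placing a ring on this nitrogen, and compound 4 stands against such a reading. Nothing at hand gives a measured reason for the difference between the cyclopentyl and cyclopropyl results.

Open is whether the cyclopropyl step carries over to the core of compound 1, since that step is shown only with the chloro group on the aromatic ring, while the cyclopentyl step is shown only without it. Also open, as far as these compounds go, is how this nitrogen would read with a cyclobutyl, a cyclohexyl, a benzyl or a longer chain, or with a substituent carrying an amine or a carboxylic acid.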